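The source may hold more compounds than are shown below. What is called first, only, known or untested is meant among the compounds shown, and "the series" means these compounds.

Compound 1 `ClC1=C(c2nnc(-c3ccccc3)o2)CCCc2ccccc21` is the starting point of the series; in a functional assay on A549 cells (Homo sapiens) for antiproliferative activity, read by sulforhodamine B assay, with a stated time of 48 h (a higher number here means a weaker inhibitor of growth, a lower number a stronger inhibitor of growth), compound 1 gives 2270 nM. Compound 2 `Cc1ccc(-c2nnc(C3=C(Cl)c4ccccc4CCC3)o2)cc1` differs from it by methyl in place of hydrogen on an aromatic carbon, and this change made a 1.5-fold higher number from compound 1 to compound 2 (0.18 log units; within the scatter); in this assay compound 2 gives 3420 nM. Compound 3 `Cc1cc2c(cc1C)C(Cl)=C(c1nnc(-c3ccccc3)o1)CCC2` carries a second core; the difference between the two cores is not broken down here. In this assay compound 3 gives 1960 nM, a number that lies within the scatter of the values of compound 1 and of compound 2, so no order among the three can be read from it.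

Compound 4 `Cc1ccc(-c2nnc(C3=C(Cl)c4cc(C)c(C)cc4CCC3)o2)cc1` has not yet been measured. It differs from compound 3 by methyl in place of hydrogen on an aromatic carbon, the same change, at the same place, as that from compound 1 to compound 2. The step from compound 3 to compound 4 is expected to be a 1.5-fold higher number from compound 3 to compound 4 (0.17 log units; within the scatter), a size that rests on the earlier pair because the same change made a 1.5-fold higher number from compound 1 to compound 2 (0.18 log units; within the scatter). The estimate for compound 4 in this assay is 2900 nM, with an expected range from 1500 nM to 6000 nM.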

Compound 4, concentration for 50% growth inhibition: 2470 nM
Compound 4: middle estimate off by 1.2-fold (0.07 log units), on the high side; the range from low to high includes it.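

Phenyl to 4-methylphenyl on the core of compound 3 gives a 1.3-fold higher number from compound 3 to compound 4 (0.10 log units; within the scatter) in this assay, and set beside the earlier step, the change reads alike on the two cores: the same change on two cores in this assay, a 1.5-fold higher number (0.18 log units; within the scatter) from compound 1 to compound 2 and a 1.3-fold higher number (0.10 log units; within the scatter) from compound 3 to compound 4, 1.2-fold (0.08 log units) apart, within the scatter of two such steps.

In this assay, the methyl therefore carries from the core of compound 1 to the core of compound 3 with no difference between the two steps that can be told from the scatter. This does not show that the methyl has any effect on growth inhibition, since neither step stands clear of the scatter, and two cores in one cell line give no rule for other cores or other assays.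

The compounds shown leave open whether any group at this place moves the number beyond the scatter, for example an amine, a carboxylic acid or a longer chain in place of the methyl. They also leave open whether such a larger step would carry from one core to the other as the methyl step does.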